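Working notes: from compound 3 to compound 4

The compounds below may be only part of what the source reports. "The series", "measured", "known", "first", "only" and "open" are said of these compounds alone.

Measured in a functional assay on MCF7 cells (Homo sapiens) for cytotoxicity, read by MTT assay, with a stated time of 72 h; on this read-out higher numbers stand for weaker inhibition and lower numbers for stronger inhibition:
compound 1 `COc1cccc(/C=C2\CCC/C(=C\c3cccc(Br)c3)C2=O)c1OC` gives 11700 nM
compound 2 `COc1cccc(/C=C2\CCC/C(=C\c3cccc(OC)c3OC)C2=O)c1` gives 5900 nM
compound 3 `COc1ccc(/C=C2\CCC/C(=C\c3cccc(Cl)c3)C2=O)cc1OC` gives 6000 nM

Compound 3 stands second highest of the three numbers; its nearest is compound 2, and its gap to compound 1 is within the scatter, so no order can be read among the three. Compound 4 `COc1ccc(/C=C2\CCC/C(=C\c3ccc(O)cc3)C2=O)cc1OC` differs from compound 3 in one place: 4-hydroxyphenyl in place of 3-chlorophenyl on a double-bonded chain carbon bound to a double-bonded ring carbon. For the measured compounds named here, the one measured step of related kind is a 2.0-fold lower number from compound 1 to compound 2 (0.30 log units; within the scatter), a halogen giving way to an oxygen-bearing group on an aromatic carbon; it stayed within the scatter. Going by the values given here, no measured step matches the full change to a hydroxyl. For compound 4 the expected step is therefore a 1.2-fold lower number from compound 3 to compound 4 (0.08 log units; within the scatter), not beyond the scatter. Compound 4 is estimated at 5000 nM, with a range from 1800 nM to 14000 nM.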

Compound 4, half-maximal inhibitory concentration: 17000 nM
Compound 4: the middle estimate sits 3.4-fold (0.53 log units) below what was measured, and the stated range ends below it.
By their numbers in this assay, from the lowest: compounds 2, 3, 1 and 4 (each within the scatter of the next, the first and the last beyond it).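

In this assay, for the compounds shown here, the swap of 3-chlorophenyl for 4-hydroxyphenyl gives a 2.8-fold higher number from compound 3 to compound 4 (0.45 log units; beyond the scatter) as the first step beyond the scatter, towards weaker inhibition. Going by these compounds alone, the earlier bromo to methoxy step stayed within the scatter, so this is the first sign that the aryl group on a double-bonded chain carbon bound to a double-bonded ring carbon can move the read-out. No supporting data bear on why the number rose.

As far as these compounds go, whether the hydroxyl itself or its place on the ring carries the step stays open. So does how 4-aminophenyl or 4-carboxyphenyl would read at this place.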